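This account rests on a few compounds, and the source may have more. Where it says the series, first, only, none or still open, it means among the compounds named here.

Compound 3 `CN(CCCN1CCCCC1)c1cccc(C(=O)N2CCc3ccc(OS(N)(=O)=O)cc3C2)c1` stands lowest of the three compounds measured in an assay on HEK293 cells for inhibition of Steryl-sulfatase (Homo sapiens), tested at 1 uM; a lower number here means a weaker effect, a higher number a stronger effect of the compound at the concentration tested: compound 3 gives 30.6%, whereas compound 1 `CC(C)CCN(CCC(C)C)c1cccc(C(=O)N2CCc3ccc(OS(N)(=O)=O)cc3C2)c1` gives 75.9% and compound 2 `CCN(Cc1ccccc1)c1cccc(C(=O)N2CCc3ccc(OS(N)(=O)=O)cc3C2)c1` gives 69%. The drops a number 45.3 percentage points lower from compound 1 to compound 3 (beyond the scatter) and a number 38.4 percentage points lower from compound 2 to compound 3 (beyond the scatter) were both large, while a number 6.9 percentage points lower from compound 1 to compound 2 (within the scatter) stayed within the scatter. Compound 4 `CCN(Cc1cccnc1)c1cccc(C(=O)N2CCc3ccc(OS(N)(=O)=O)cc3C2)c1` reverses the direction of that last change: ethyl((pyridin-3-yl)methyl)amino in place of methyl(3-(piperidin-1-yl)propyl)amino on an aromatic carbon. The six-membered non-aromatic ring with one hetero atom gives way to a six-membered aromatic ring with one hetero atom, and the group now carries an ethyl arm as in compound 2. Because the step of a number 38.4 percentage points lower from compound 2 to compound 3 (beyond the scatter) was large, a large rise is expected, a number 29.4 percentage points higher from compound 3 to compound 4 (beyond the scatter). Compound 4 is therefore estimated at 60%, in the range 40% to 78%.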

Compound 4, a percentage reported as inhibition, at one concentration (the size of the read-out at that concentration, not a potency): 33.5%
For compound 4 the middle estimate is 26.5 percentage points above the measured one; measured number below the stated range.
By their numbers in this assay, from the lowest: compounds 3 and 4 (each within the scatter of the next); then compounds 2 and 1 (each within the scatter of the next).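

In this assay, pyridin-3-yl in place of phenyl on a saturated chain carbon bound to a nitrogen on an aromatic ring gives a number 35.5 percentage points lower from compound 2 to compound 4 (beyond the scatter), so this single ring change is enough for a large loss. The other two steps, a number 42.4 percentage points lower from compound 1 to compound 4 (beyond the scatter) and a number 2.9 percentage points higher from compound 3 to compound 4 (within the scatter), place compound 4 with compound 3, and among these compounds the two groups holding a second nitrogen give the low read-outs. Nothing measured here accounts for this. Going by these compounds, whether a pyridin-2-yl or pyridin-4-yl ring, or a phenyl carrying a methoxy group, would keep the read-out remains open.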